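Swapping a bromo for a methyl on the shared core

The source may report more compounds than this note shows. Statements on the series, on what has been measured and on what is new or still open speak of the compounds shown alone.

Measured so far:
Compound 1, `Clc1ccc(OCC2=NCCO2)cc1`: 30%
Compound 2, `Brc1ccccc1OCC1=NCCO1`: 70%

Both compounds were tested in a toxicity assay on the whole organism with Rattus norvegicus as the target, at a dose of 100 mg/kg by the oral route; on this read-out higher numbers stand for a stronger effect at the one dose given and lower numbers for a weaker effect. In this assay compound 1 gives 30%, while compound 2 gives 70%. Among the measured compounds shown here, of the two numbers measured so far, compound 2 stands highest; its nearest neighbour is compound 1, and the gap between them is well beyond the usual scatter of such measurements. The two compounds differ in more than one place, so their values are simply noted side by side here.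

The next compound is compound 3, `Cc1ccccc1OCC1=NCCO1`. Compared with compound 2 it carries one change, (methyl in place of bromo on an aromatic carbon). For the measured compounds named here, no step of this kind has been measured, so there is nothing to copy from. Compound 3 is therefore expected to land somewhat below compound 2, a step of a number 15 percentage points lower from compound 2 to compound 3 (beyond the scatter) that reaches just beyond the scatter, with wide uncertainty. The estimate for compound 3 in this assay is 55%, expected to fall between 30% and 80%.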

Compound 3, a percentage reported as activity, at one dose (the size of the read-out at that dose, not a potency): 40%
Estimate against measurement, compound 3: 15 percentage points above; the range from low to high includes it.
By their numbers in this assay, from the lowest: compounds 1 and 3 (each within the scatter of the next); then compound 2.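

In this assay, putting a methyl in place of the bromo on an aromatic carbon, ortho to a group of 7 heavy atoms, gives a number 30 percentage points lower from compound 2 to compound 3 (beyond the scatter). Among the compounds shown here, this is the first comparison that changes only one place, so it shows that the read-out depends on which group sits at this position. The change is also a close one on paper, since one heavy atom replaces another and neither group brings a ring, a charge, or any hydrogen-bond donors or acceptors, yet the data shown offer no explanation for the shift.

Going by these compounds, what stays open is how far this holds beyond a single pair: an amine, a methoxy group or a carboxylic acid on the same aromatic carbon could land near compound 2, near compound 3 or somewhere else entirely in this assay. On these data alone, a longer chain such as ethyl or propyl in place of the methyl would test whether the read-out keeps moving as the group grows, and the effect of this swap on other parts of the shared core also remains unknown.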